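Cytotoxicity of three aminated bicyclic aryl compounds and a fourth

The source may report more compounds than this note shows. Statements on the series, on what has been measured and on what is new or still open speak of the compounds shown alone.

Compound 1, `CCCCOc1ccc(-c2nc3ncccn3c2Nc2ccccc2)cc1`, in a toxicity assay on A549 cells (Homo sapiens) for cytotoxicity, read by luminescence and CellTiter-Glo, with a stated time of 48 h (on this read-out higher numbers stand for lower toxicity in this test and lower numbers for higher toxicity in this test), gives 100000 nM.
Compound 2, `COCCOc1ccc(-c2nc3ncccn3c2NC2CCCCC2)cc1`, reaches only the limit > 100000 nM in this assay.
Compound 3, `Brc1ccc(-c2nc3ncccn3c2Nc2ccccc2)cc1`, reaches only the limit > 100000 nM in this assay.

Compound 3 stands at a limit of this assay, not at a number; its value is a limit. The step of a number no lower from compound 1 to compound 3 (the limit leaves the size open) is therefore of unreadable size, since it ends at a limit. Two of the three values shown sit at that same limit, (the limit of > 100000 nM in this assay, at which 2 of the 3 values shown sit), and the third, that of compound 1, sits at the same figure as a measured number, so none of the three compounds shows toxicity that this assay can resolve.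

Compound 4, `COCCOc1ccc(-c2nc3ncccn3c2Nc2ccccc2)cc1`, differs from compound 3 by 2-methoxyethoxy in place of bromo on an aromatic carbon. Among the compounds with values here, no measured step covers this exact exchange. Compound 2 carries the same 2-methoxyethoxy group with a different amine and reaches only a limit, and compound 3 itself stands at a limit, so no shift beyond the scatter is expected in this assay for compound 4; the step of a number no higher from compound 3 to compound 4 (the limit leaves the size open) is estimated as flat. Compound 4 is expected to give about 100000 nM, within 50000 nM to 200000 nM, most likely again reported as a limit.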

Compound 4, half-maximal cytotoxic concentration: > 100000 nM
Compound 4 ended at the assay's limit (the forecaster's own chance of this, stated with the estimate: 70%); the middle value lies on the limit itself.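

In this assay the value of compound 4 is a limit, and it joins the other two limits: the limit of > 100000 nM in this assay, at which 3 of the 4 values shown sit.
The 2-methoxyethoxy group, on an aromatic carbon para to a large group, now appears with the phenyl on the nitrogen as well as with the cyclohexyl of compound 2, and neither compound reaches a number in this assay. Within the data shown here, the step of a number no lower from compound 1 to compound 4 (the limit leaves the size open) is the only new step that starts from a number. The other two new steps cannot be read. Only compound 1 gives 100000 nM as a number.

The compounds shown leave open whether any group at this place brings a value that this assay can resolve. A longer chain, or a chain ending in an amine or a carboxylic acid, could test this on the shared core.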